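Sulfonamide aryl group: tert-butyl to trifluoromethyl

A few compounds are considered here, and "the series" means these few. Any claim that something is new, unique, unknown or untested is made for them only; others in the source may bear on it.

In a functional assay on DU-145 cells (Homo sapiens) for inhibition, read by CCK-8 assay, with a stated time of 72 h (a lower number here means a stronger inhibitor, a higher number a weaker inhibitor), compound 1 `Cc1ccccc1NS(=O)(=O)c1cccc(CCCCCCNC(=O)/C=C/c2cccnc2)c1` gives 2.9 nM and compound 2 `Cc1ccc(C)c(NS(=O)(=O)c2cccc(CCCCCCNC(=O)/C=C/c3cccnc3)c2)c1` gives 7.48 nM. Compound 3 `CC(C)(C)c1ccc(NS(=O)(=O)c2cccc(CCCCCCNC(=O)/C=C/c3cccnc3)c2)cc1` gives 281 nM, the highest number of the three and so the weakest inhibitor measured so far. Compound 4 `O=C(/C=C/c1cccnc1)NCCCCCCc1cccc(S(=O)(=O)Nc2ccc(C(F)(F)F)cc2)c1` is not yet measured and differs from compound 3 by trifluoromethyl in place of tert-butyl on an aromatic carbon, para to a large group.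

Going by the values given here, two measured steps bear on this change. Putting 4-(tert-butyl)phenyl in place of 2-methylphenyl on the sulfonamide nitrogen gave a 97-fold higher number from compound 1 to compound 3 (1.99 log units; beyond the scatter), and putting it in place of 2,5-dimethylphenyl gave a 38-fold higher number from compound 2 to compound 3 (1.57 log units; beyond the scatter). Both are large, whereas adding a methyl gave only the modest 2.6-fold higher number from compound 1 to compound 2 (0.41 log units; beyond the scatter). Among the compounds with values here, no measured compound carries trifluoromethyl, and only one carries tert-butyl, so these steps set the direction but not the size. Removing the tert-butyl should recover part of the gap, not all of it. The expected move is a sizeable drop, estimated as a 9.4-fold lower number from compound 3 to compound 4 (0.97 log units; beyond the scatter). For compound 4 the estimated value in this assay is 30 nM, with an expected range of 6 nM to 150 nM.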

Compound 4, half-maximal inhibitory concentration: 1410 nM
The estimate for compound 4 lay 47-fold (1.67 log units) below the measured number, outside the stated range (above it).
By their numbers in this assay, from the lowest: compound 1; then compound 2; then compound 3; then compound 4.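

In this assay, trifluoromethyl in place of tert-butyl on an aromatic carbon, para to a large group, keeps the count of heavy atoms but does not recover activity, giving a 5.0-fold higher number from compound 3 to compound 4 (0.70 log units; beyond the scatter) and leaving compound 4 the weakest inhibitor of the four. Going by these compounds alone, the low numbers therefore do not return simply on removing tert-butyl, and the gap to the aryl groups of the earlier compounds widens, with a 190-fold higher number from compound 2 to compound 4 (2.28 log units; beyond the scatter) for 4-(trifluoromethyl)phenyl in place of 2,5-dimethylphenyl and a 490-fold higher number from compound 1 to compound 4 (2.69 log units; beyond the scatter) for the same group in place of 2-methylphenyl. No measurement available here accounts for the step from tert-butyl to trifluoromethyl or for the size of these losses.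

The compounds shown do not separate the effect of a group at this para position from the loss of the methyl carried by compound 1 and compound 2, since compound 3 and compound 4 differ from those compounds in both respects. Still open, from the compounds shown here alone, is how an unsubstituted phenyl, a 4-methylphenyl, a 4-methoxyphenyl or a 4-aminophenyl on the sulfonamide nitrogen would read in this assay against these four compounds.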